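The source may report more compounds than this note shows. Statements on the series, on what has been measured and on what is new or still open speak of the compounds shown alone.

Four compounds share one core. Compound 1 `CCCCOc1ccc(NS(=O)(=O)c2ccc(N3CCNC3=O)cc2)cc1` gives 630 nM in a functional assay on HT-29 cells (Homo sapiens) for antiproliferative activity, read by sulforhodamine B assay, with a stated time of 48 h; a higher number here means a weaker inhibitor, a lower number a stronger inhibitor. Compound 2 `O=C1NCCN1c1ccc(S(=O)(=O)Nc2ccc(F)c(F)c2)cc1` gives 350 nM in this assay, a number that sits within the usual scatter of compound 1's 630 nM, so no order between these two can be claimed. Compound 3 `CC(C)Cc1ccc(NS(=O)(=O)c2ccc(N3CCNC3=O)cc2)cc1` reaches only a limit, > 1000 nM, in this assay. The measured step of an at least 1.5-fold higher number from compound 1 to compound 3 (0.20 log units; that floor lies within the scatter) rests on (the limit of > 1000 nM in this assay, at which 1 of the 3 values shown sits). Compound 4 `O=C1NCCN1c1ccc(S(=O)(=O)Nc2cccc(Cl)c2)cc1` is not yet measured; it differs from compound 2 by 3-chlorophenyl in place of 3,4-difluorophenyl on a sulfonamide nitrogen. Among the compounds with values here, the one measured step swaps a different group within the part attached to the sulfonamide nitrogen, so it gives no guide to exchanging one halogen pattern for another, and no step beyond the scatter is expected. Compound 4 is therefore estimated at 450 nM, between 200 nM and 1000 nM, an expected step of a 1.3-fold higher number from compound 2 to compound 4 (0.11 log units; within the scatter).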

Compound 4, half-maximal inhibitory concentration: 55 nM
Compound 4: the middle estimate sits 8.2-fold (0.91 log units) above what was measured; the measured number lies below the stated range.
By their numbers in this assay, from the lowest: compound 4; then compounds 2 and 1 (each within the scatter of the next). At a limit, above all of these: compound 3.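

In this assay, within the data shown here, the swap to 3-chlorophenyl in place of 3,4-difluorophenyl on the sulfonamide nitrogen gives a 6.4-fold lower number from compound 2 to compound 4 (0.80 log units; beyond the scatter), the first step that lies beyond the scatter. So this position can respond clearly to which halogenated phenyl it carries, something compound 1, compound 2 and compound 3 could not show. Nothing measured here explains the size of this step.

Going by these compounds, it remains open whether chlorine itself or the loss of the fluorines carries the step. Also open, on these data alone, is how a bromine or a methoxy group in place of that chlorine would behave.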